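Bromo for Trifluoromethyl on a Benzyl Arm

The compounds below may be only part of what the source reports. "The series", "measured", "known", "first", "only" and "open" are said of these compounds alone.

Three compounds sharing one core have been examined in a physicochemical assay for solubility, read by HPLC, with a stated time of 12 h, at pH 2; on this read-out lower numbers stand for lower solubility and higher numbers for higher solubility. Compound 1 `O=c1nc(N2CCN(CC3CCCCC3)CC2)sc2c([N+](=O)[O-])cc(C(F)(F)F)cc12` gives 0.9 ug/mL in this assay. Compound 2 `CCOC(=O)CN1CCC2(CCN(c3nc(=O)c4cc(C(F)(F)F)cc([N+](=O)[O-])c4s3)CC2)C1` gives 2.04 ug/mL. Compound 3 `O=c1nc(N2CCC3(CCN(Cc4ccc(C(F)(F)F)cc4)CC3)CC2)sc2c([N+](=O)[O-])cc(C(F)(F)F)cc12` gives 1.24 ug/mL, a number that sits within the usual scatter of the result for compound 1 and also within the scatter of the result for compound 2, so the three numbers cannot be ordered with confidence.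

Compound 4 `O=c1nc(N2CCC3(CCN(Cc4ccc(Br)cc4)CC3)CC2)sc2c([N+](=O)[O-])cc(C(F)(F)F)cc12` has not yet been measured. It differs from compound 3 in one place: bromo in place of trifluoromethyl on an aromatic carbon. Among the compounds with values here, no pair of measured compounds shows this difference, so its effect in this assay is not known from the data at hand. Given that compounds 1, 2 and 3 all lie close together, compound 4 is expected to stay in the same neighbourhood, with a step of a 1.0-fold higher number from compound 3 to compound 4 (0.02 log units; within the scatter) that amounts to no change beyond the scatter. Compound 4 is therefore estimated to give 1.3 ug/mL, within a range of 0.5 ug/mL to 3.5 ug/mL.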

Compound 4, solubility: 1.17 ug/mL
The estimate for compound 4 lay 1.1-fold (0.05 log units) above the measured number; the measured number falls inside the stated range.
By their numbers in this assay, from the lowest: compounds 1, 4, 3 and 2 (each within the scatter of the next, the first and the last beyond it).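

In this assay, within the data shown here, bromo in place of trifluoromethyl on this aromatic carbon, para to a large group, gives a 1.1-fold lower number from compound 3 to compound 4 (0.03 log units; within the scatter), the first direct reading of this change. Four heavy atoms leave and one enters, with no hydrogen-bond donors or acceptors on either side, and the read-out does not separate the two compounds. Nothing at hand offers an explanation for this result.

The compounds shown do not say whether this position would respond to a group of another kind, such as an amine or a carboxylic acid on the same aromatic carbon. Nor do they say whether the same exchange of trifluoromethyl for bromo would read alike on another arm of the shared core.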